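A few compounds are considered here, and "the series" means these few. Any claim that something is new, unique, unknown or untested is made for them only; others in the source may bear on it.

Measured so far in an assay on IMR-32 cells for displacement of a labelled ligand from corticotropin-releasing factor receptor 1 (Homo sapiens), read by scintillation counting, with a stated time of 2 h; a higher number here means a weaker inhibitor, a lower number a stronger inhibitor:
compound 1 `CCc1nc(NC(CC)CC)c(Cl)nc1-c1ccc(Cl)cc1Cl` gives 71 nM
compound 2 `CCc1nc(-c2ccc(OC(F)(F)F)cc2OC)c(CC)nc1NC(CC)CC` gives 7.2 nM
compound 3 `CCc1nc(-c2ccc(Cl)cc2Cl)c(CC)nc1NC(COC)COC` gives 224 nM

Compound 1 stands second highest of the three numbers in this assay. Its nearest neighbour is compound 3, whose number is higher by a margin beyond the usual scatter; compound 2 is furthest away, with a lower number, again beyond the scatter. The three measured compounds differ from one another in more than one place, so none of these gaps can be tied to a single structural change.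

Compound 4 `CCOc1nc(-c2ccc(Cl)cc2Cl)c(CC)nc1NC(CC)CC` has not been measured. It differs from compound 1 in one place: ethoxy in place of chloro on an aromatic carbon. For the measured compounds named here, no pair of measured compounds isolates this change, so no measured step shows its direction or size. Compounds 2 and 3 sit on both sides of compound 1 while differing from it in several places, which leaves the effect of this single substitution undetermined. The expectation for compound 4 in this assay is therefore a step of modest size, most likely within the scatter, with a slight lean toward a lower number. Compound 4 is estimated at 50 nM, with a range from 15 nM to 200 nM. The expected step is a 1.4-fold lower number from compound 1 to compound 4 (0.15 log units; within the scatter), small by this estimate.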

Compound 4, inhibition constant: 151 nM
For compound 4 the middle estimate is 3.0-fold (0.48 log units) below the measured one, and the stated range covers the measured number.
By their numbers in this assay, from the lowest: compound 2; then compound 1; then compounds 4 and 3 (each within the scatter of the next).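

On the shared core, the aromatic carbon next to the ring nitrogen and ortho to the (pentan-3-yl)amino group now has its first single-place comparison: in this assay, ethoxy in place of chloro gives a 2.1-fold higher number from compound 1 to compound 4 (0.33 log units; beyond the scatter) on this core. The step is modest, and the position carries the 3 heavy atoms of ethoxy in place of a single chlorine with compound 4 still at 151 nM in this binding read-out, so the larger group costs some affinity without removing it. Nothing measured on these compounds bears on why the step has this direction or size.

Still open, from the compounds shown here alone, is whether the step follows the ether oxygen or the length of the chain at this carbon; a methyl, a propoxy chain or a dimethylamino group here, on an otherwise unchanged core, would begin to separate those two readings. Also open, going by these compounds, is whether the same step holds with the 2,4-dichlorophenyl ring replaced or with another amino group in place of (pentan-3-yl)amino, since this single pair tests the change on one background only.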